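The source may hold more compounds than are shown below. What is called first, only, known or untested is meant among the compounds shown, and "the series" means these compounds.

Measured compounds in a functional assay on SK-MEL-2 cells (Homo sapiens) for cytotoxicity, read by sulforhodamine B assay, with a stated time of 2 days, tested at 100 uM; on this read-out higher numbers stand for more inhibition at the one concentration tested (going by the name of the read-out) and lower numbers for less inhibition:
- Compound 1, `O=C(Nn1c(-c2cccc([N+](=O)[O-])c2)nc2c(-c3ccc(F)cc3)n[nH]c2c1=O)c1cccnc1`: compound 1 gives 24.5%
- Compound 2, `O=C(Nn1c(-c2cccc([N+](=O)[O-])c2)nc2c(-c3ccco3)n[nH]c2c1=O)c1cccnc1`: compound 2 gives 19.2%
- Compound 3, `COc1cccc(-c2nc3c(-c4ccco4)n[nH]c3c(=O)n2NC(=O)c2cccnc2)c1`: compound 3 gives 34.1%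

Compound 2 has the lowest of the three numbers. Its nearest neighbour is compound 1, and that pair differs only within the scatter, as a number 5.3 percentage points lower from compound 1 to compound 2 (within the scatter) shows. The furthest is compound 3, reached through a number 14.9 percentage points higher from compound 2 to compound 3 (beyond the scatter), a change that replaces nitro by methoxy on an aromatic carbon.

Compound 4, `O=C(Nn1c(-c2cccc([N+](=O)[O-])c2)nc2c(CCc3ccccc3)n[nH]c2c1=O)c1cccnc1`, is not yet measured. It differs from compound 2 in one place: phenethyl in place of furan-2-yl on an aromatic carbon

Among the compounds with values here, of the measured steps, only the one from compound 1 to compound 2 concerns the same aromatic carbon, and it stayed within the scatter, a number 5.3 percentage points lower from compound 1 to compound 2 (within the scatter). The step to compound 3 concerns another position and does not bear on this change. Within the data shown here, no measured pair shows a phenethyl group, so its effect is unknown. Compound 4 is therefore expected to give about 22% in this assay, with a range from 8% to 38%, and the expected step of a number 2.8 percentage points higher from compound 2 to compound 4 (within the scatter) is estimated not to go beyond the scatter.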

Compound 4, a percentage reported as inhibition, at one concentration (the size of the read-out at that concentration, not a potency): 28.5%
Compound 4: the middle estimate sits 6.5 percentage points below what was measured; the measured number falls inside the stated range.
By their numbers in this assay, from the lowest: compounds 2, 1, 4 and 3 (each within the scatter of the next, the first and the last beyond it).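

In this assay, with nitro held constant, phenethyl on this aromatic carbon of the five-membered ring stays within the scatter of both groups it can be compared with, furan-2-yl (a number 9.3 percentage points higher from compound 2 to compound 4 (within the scatter)) and 4-fluorophenyl (a number 4 percentage points higher from compound 1 to compound 4 (within the scatter)). The earlier compounds shown here carried only an aromatic ring attached directly at this carbon, whereas compound 4 carries its ring on a chain, with 8 heavy atoms in place of the 5 of furan-2-yl and no hydrogen-bond acceptor in that group. This position has therefore taken three differently built groups without any step going beyond the scatter.

On these data alone, whether an amine, a carboxylic acid or a longer chain at this carbon would give a step beyond the scatter remains open, as does whether phenethyl behaves the same way with methoxy in place of nitro. No evidence is at hand that would account for these numbers.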